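Swapping Cyclohexyl for a Chloropyridinyl Group on the Amide

This account rests on a few compounds, and the source may have more. Where it says the series, first, only, none or still open, it means among the compounds named here.

compound 1 `Cc1noc(C)c1-c1cnc(N)c(Oc2ccc(C(=O)NC3CCCCC3)cc2)n1` — 40400 nM
compound 2 `Cc1noc(C)c1-c1cnc(N)c(Oc2ccc(C(=O)Nc3ccccc3Cl)cc2)n1` — 60500 nM
compound 3 `Cc1noc(C)c1-c1cnc(N)c(Oc2ccc(C(=O)Nc3cc(Cl)ccn3)cc2)n1` — 70800 nM

Of the compounds shown here, three sharing one core have been tested in a functional assay on U-87MG ATCC cells for inhibition, with U-87 MG (Homo sapiens) as the target, read by MTT assay, with a stated time of 72 h (a lower number here means a stronger inhibitor, a higher number a weaker inhibitor), and all three give high numbers, meaning weak inhibition. Compound 1 holds the lowest of the three numbers, but neither neighbour is separated from it beyond the scatter: a 1.5-fold higher number from compound 1 to compound 2 (0.18 log units; within the scatter) and a 1.8-fold higher number from compound 1 to compound 3 (0.24 log units; within the scatter). Between the two compounds carrying an aromatic group on the amide nitrogen, a 1.2-fold higher number from compound 2 to compound 3 (0.07 log units; within the scatter).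

Compound 4 `Cc1noc(C)c1-c1cnc(N)c(Oc2ccc(C(=O)Nc3ncccc3Cl)cc2)n1` differs from compound 1 in one place: 3-chloropyridin-2-yl in place of cyclohexyl on an amide-type nitrogen. The closest comparisons are the two steps already seen from compound 1, where 2-chlorophenyl and 4-chloropyridin-2-yl each replaced cyclohexyl on the same amide nitrogen and moved the number only slightly upward, within the scatter. A 3-chloropyridin-2-yl group is another chlorinated aromatic ring in the same position, so for compound 4 a comparable outcome is expected in this assay, at most a small rise and nothing beyond the scatter, an expected step of a 1.5-fold higher number from compound 1 to compound 4 (0.17 log units; within the scatter). Compound 4 is therefore estimated at 60000 nM, with a likely range from 25000 nM to 150000 nM.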

Compound 4, half-maximal inhibitory concentration: 45600 nM
Compound 4: the middle estimate sits 1.3-fold (0.12 log units) above what was measured, within the range that was stated.
By their numbers in this assay, from the lowest: compounds 1, 4, 2 and 3 (each within the scatter of the next).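

Compound 4 puts a third chlorinated aromatic group on the amide-type nitrogen, and in this assay it reads level with the cyclohexyl group, with a 1.1-fold higher number from compound 1 to compound 4 (0.05 log units; within the scatter). Among the chlorinated aromatic groups, the new 3-chloropyridin-2-yl group also adds no separation: 4-chloropyridin-2-yl in its place gives a 1.6-fold lower number from compound 3 to compound 4 (0.19 log units; within the scatter), and 2-chlorophenyl in its place gives a 1.3-fold lower number from compound 2 to compound 4 (0.12 log units; within the scatter), so the chlorinated rings shown cannot be told apart at this position. No measurement at hand explains why these groups read alike.

From the compounds shown here alone, all four numbers remain high, so it stays open whether any change at this nitrogen can bring a number clearly lower. Also open, going by these compounds, is how a ring carrying an amine or a carboxylic acid, or a longer carbon chain in place of the ring, would read.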